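The source may report more compounds than this note shows. Statements on the series, on what has been measured and on what is new or still open speak of the compounds shown alone.

Two coumarin-type amides built on the same core have been measured for their effect on the growth of breast cancer cells. Compound 1 `CC(=O)Oc1ccc(C(=O)Nc2cc3ccc(OCC4CCN(C)C4)c(C)c3oc2=O)cc1CC=C(C)C` gives 880 nM in a functional assay on SK-BR-3 cells (Homo sapiens) for antiproliferative activity; on this read-out lower numbers stand for stronger inhibition and higher numbers for weaker inhibition. Compound 2 `CC(C)=CCc1cc(C(=O)Nc2cc3ccc(OCCCNC(C)C)c(C)c3oc2=O)ccc1O` gives 750 nM in this assay, the lower of the two numbers, though its gap to compound 1 stays within the scatter of repeated measurements, so the two cannot be told apart.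

Compound 3 `CC(C)=CCc1cc(C(=O)Nc2cc3ccc(OCCCNC(C)(C)c4ccccc4)c(C)c3oc2=O)ccc1O` is the next compound to be tested. It differs from compound 2 in one place: phenyl in place of hydrogen on a saturated chain carbon bound to an amine nitrogen and two saturated chain carbons. Going by the values given here, no measured pair with this kind of change exists here, so its effect cannot be read off a known step.

Compound 3 is expected to give 600 nM in this assay, with a range from 200 nM to 2000 nM. The step expected from this is a 1.3-fold lower number from compound 2 to compound 3 (0.10 log units; within the scatter), which is taken to be no change beyond the scatter, since nothing measured points in either direction.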

Compound 3, half-maximal inhibitory concentration: 960 nM
Compound 3: the middle estimate sits 1.6-fold (0.20 log units) below what was measured, within the range that was stated.
By their numbers in this assay, from the lowest: compounds 2, 1 and 3 (each within the scatter of the next).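

In this assay, phenyl in place of hydrogen on a saturated chain carbon bound to an amine nitrogen and two saturated chain carbons gives a 1.3-fold higher number from compound 2 to compound 3 (0.11 log units; within the scatter), so isopropylamino and (1-methyl-1-phenylethyl)amino cannot be told apart on this read-out. Going by these compounds alone, this is the first step that differs in one place, and it shows that this position can carry one six-membered aromatic ring of carbon with no change beyond the scatter. No measurement shown here bears on the reason for this result.

The compounds shown leave open whether a different group at this place, such as a carboxylic acid, a pyridine ring or a longer chain, would move the number beyond the scatter. They also leave open how a primary amine in place of isopropylamino would read in this assay.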